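The source may report more compounds than this note shows. Statements on the series, on what has been measured and on what is new or still open speak of the compounds shown alone.

Working notes on the series. Compound 1 `COc1cc(N2C(=O)C(O)C2c2ccc(SC)cc2)cc(OC)c1OC`, compound 2 `CCSc1ccc(C2CC(=O)N2c2cc(OC)c(OC)c(OC)c2)cc1` and compound 3 `C=CC1C(=O)N(c2cc(OC)c(OC)c(OC)c2)C1c1ccc(SCC)cc1` share one core and differ at the saturated ring carbon and on the aryl sulfur substituent. In a functional assay on HL-60 cells (Homo sapiens) for inhibition, read by resazurin assay, with a stated time of 72 h (on this read-out lower numbers stand for stronger inhibition and higher numbers for weaker inhibition), compound 1 gives 15 nM, compound 2 gives 204 nM and compound 3 gives 320 nM. Compound 3 thus stands highest of the three numbers, nearest compound 2 and furthest from compound 1. For the measured compounds named here, the only step between compounds differing in one place, a 1.6-fold higher number from compound 2 to compound 3 (0.20 log units; within the scatter), is vinyl in place of hydrogen, within the scatter. Compound 4 `CCSc1ccc(C2C(O)C(=O)N2c2cc(OC)c(OC)c(OC)c2)cc1` follows from compound 3 by hydroxy in place of vinyl on a saturated ring carbon. Compound 1 also carries the hydroxy there and gives 15 nM, while compound 3 gives 320 nM; the two differ in a second place, so this is suggestive only, but it points to a lower number. Compound 4 is therefore expected at 30 nM, between 10 nM and 90 nM. The expected step is an 11-fold lower number from compound 3 to compound 4 (1.03 log units; beyond the scatter).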

Compound 4, half-maximal inhibitory concentration: 16 nM
Compound 4: middle estimate off by 1.9-fold (0.27 log units), on the high side; measured number inside the range.
By their numbers in this assay, from the lowest: compounds 1 and 4 (each within the scatter of the next); then compounds 2 and 3 (each within the scatter of the next).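

In this assay the saturated ring carbon proves sensitive to the group it carries: hydroxy gives a large step against both hydrogen (a 13-fold lower number from compound 2 to compound 4 (1.11 log units; beyond the scatter)) and vinyl (a 20-fold lower number from compound 3 to compound 4 (1.30 log units; beyond the scatter)), although vinyl against hydrogen alone stayed within the scatter. With hydroxy in place, methyl added to the sulfur chain makes no difference beyond the scatter (a 1.1-fold higher number from compound 1 to compound 4 (0.03 log units; within the scatter)). No measurement shown here explains the effect of the hydroxy. Open, going by these compounds, is whether an amine or a methoxy on that ring carbon would match hydroxy, and how a longer chain on the sulfur would fare with hydroxy present.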